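Ring exchange on the amine nitrogen: compound 2 to compound 4

The source may hold more compounds than are shown below. What is called first, only, known or untested is meant among the compounds shown, and "the series" means these compounds.

Working notes on a series of amino esters sharing one core. Compound 2 `COC(=O)c1sc2cc(Nc3ccccc3Br)cnc2c1N` gives 30900 nM in a functional assay on NCI-H460 cells (Homo sapiens) for inhibition, read by sulforhodamine B assay, with a stated time of 48 h; a higher number here means a weaker inhibitor of growth, a lower number a stronger inhibitor of growth. Among the three numbers measured so far it is nominally the second highest, but all three lie within the scatter of one another: compound 3 `COC(=O)c1sc2cc(Nc3ccc(F)cc3Br)cnc2c1N` gives 31300 nM, the step of a 1.0-fold higher number from compound 2 to compound 3 (0.01 log units; within the scatter) being within the scatter, and compound 1 `COC(=O)c1sc2cc(Nc3ccc(OC)cc3OC)cnc2c1N` gives 26300 nM, a difference from compound 2 that is also within the scatter.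

Compound 4 `COC(=O)c1sc2cc(Nc3cccnc3)cnc2c1N` differs from compound 2 by pyridin-3-yl in place of 2-bromophenyl on a nitrogen on an aromatic ring. Within the data shown here, no measured step exchanges one ring for another on that nitrogen. Among the measured compounds shown here, the only step touching the aryl group is a 1.0-fold higher number from compound 2 to compound 3 (0.01 log units; within the scatter), which adds a fluoro and stays within the scatter; compound 1, with two methoxy groups on its ring, likewise gives a number within the scatter of compound 2. The measured compounds therefore give no ground to expect a step beyond the scatter in this assay for this exchange, in either direction. Compound 4 is estimated at 30000 nM in this assay, with a range of 10000 nM to 90000 nM. On these data alone, the expected step of a 1.0-fold lower number from compound 2 to compound 4 (0.01 log units; within the scatter) is thus expected to remain within the scatter, the range widened because the ring exchange itself is untested.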

Compound 4, concentration for 50% growth inhibition: 49400 nM
Estimate against measurement, compound 4: 1.6-fold (0.22 log units) below; the range from low to high includes it.
By their numbers in this assay, from the lowest: compounds 1, 2, 3 and 4 (each within the scatter of the next).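

Among these compounds, the exchange of 2-bromophenyl for pyridin-3-yl on a nitrogen on an aromatic ring is the first ring exchange read at this position, and in this assay it gives a 1.6-fold higher number from compound 2 to compound 4 (0.20 log units; within the scatter). The earlier compounds shown here varied only groups on a benzene ring, whereas compound 4 shows that a ring with a hetero atom and no bromine can stand on this nitrogen without a step beyond the scatter. Nothing measured alongside these numbers bears on this result or accounts for the size of the step.

All compounds shown keep a six-membered aromatic ring on this nitrogen and the methyl ester on the shared core, so it remains open whether a cyclohexyl group on the nitrogen, or a carboxylic acid in place of the ester, would give a step beyond the scatter. On these data alone, it also remains open whether a pyridin-3-yl ring carrying a fluoro or methoxy group would stay within the scatter of compound 4.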